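Replacing the carbamate-side group on compound 2 with a chloropyrimidine

A few compounds are considered here, and "the series" means these few. Any claim that something is new, unique, unknown or untested is made for them only; others in the source may bear on it.

Of the compounds shown here, three sharing one core have been measured in a functional assay on isolated protein for inhibition of Glucose-dependent insulinotropic receptor (Rattus norvegicus), read by HTRF and cAMP accumulation; a higher number here means a larger maximal response, a lower number a smaller maximal response. Compound 1 `Cc1nc(S(C)(=O)=O)ccc1Oc1ncnc(OC2CCN(C(=O)OC(C)(C)CF)CC2)c1F` gives 95%, compound 2 `Cc1nc(S(C)(=O)=O)ccc1Oc1ncnc(OC2CCN(C(=O)OC3(C(F)(F)F)COC3)CC2)c1F` gives 84%, and compound 3 `Cc1nc(S(C)(=O)=O)ccc1Oc1ncnc(OC2CCN(C(=S)OC(C)C)CC2)c1F` gives 47%. Compound 2 thus stands second highest of the three: the step of a number 11 percentage points lower from compound 1 to compound 2 (beyond the scatter) is modest, while the step of a number 37 percentage points lower from compound 2 to compound 3 (beyond the scatter) is large.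

Compound 4 `Cc1nc(S(C)(=O)=O)ccc1Oc1ncnc(OC2CCN(C(=O)c3ncc(Cl)cn3)CC2)c1F` differs from compound 2 in one place: 5-chloropyrimidin-2-yl in place of (3-(trifluoromethyl)oxetan-3-yl)oxy on a carbonyl carbon.

Going by the values given here, two measured steps bear on this. Exchanging one group for another on an oxygen next to a carbonyl group gave the modest step of a number 11 percentage points lower from compound 1 to compound 2 (beyond the scatter). Exchanging the whole group on the amine nitrogen in the ring gave the large steps of a number 48 percentage points lower from compound 1 to compound 3 (beyond the scatter) and a number 37 percentage points lower from compound 2 to compound 3 (beyond the scatter). The change to compound 4 is of the second, deeper kind, so a drop beyond the scatter is expected, though with wide uncertainty. For compound 4 the expected step is a number 19 percentage points lower from compound 2 to compound 4 (beyond the scatter), giving an estimate of 65% with a range from 35% to 95%.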

Compound 4, largest response reached (reported as efficacy), in percent of the reference or control that the assay uses: 77%
The estimate for compound 4 lay 12 percentage points below the measured number; low and high end bracket the measured number.
By their numbers in this assay, from the lowest: compound 3; then compounds 4 and 2 (each within the scatter of the next); then compound 1.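

In this assay, the exchange on the carbonyl carbon gave a number 7 percentage points lower from compound 2 to compound 4 (within the scatter) and so showed that 5-chloropyrimidin-2-yl, which puts no oxygen on that carbon, can stand in for (3-(trifluoromethyl)oxetan-3-yl)oxy in this series. Compound 4 still does not reach compound 1, as a number 18 percentage points lower from compound 1 to compound 4 (beyond the scatter) shows, but a number 30 percentage points higher from compound 3 to compound 4 (beyond the scatter) shows that replacing the whole group on the amine nitrogen in the ring need not bring the large loss seen with compound 3. No measurement shown here accounts for these steps.

The compounds shown leave open whether the chlorine matters, since a nitrile, a methyl group or plain hydrogen in its place would test this. On these data alone, it also remains open whether a phenyl ring or an amine on the carbonyl carbon would hold the response.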